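Swapping Fluoro for Chloro on an Aromatic Carbon

The source may report more compounds than this note shows. Statements on the series, on what has been measured and on what is new or still open speak of the compounds shown alone.

Among the compounds with values here, compound 1 `COc1cc(CCc2ccc(F)cc2)cc(OC)c1O` holds the lower of the two numbers measured so far. In a functional assay on HCT-116 cells (Homo sapiens) for antiproliferative activity, read by MTT assay, with a stated time of 72 h (on this read-out higher numbers stand for weaker inhibition and lower numbers for stronger inhibition), compound 1 gives 1190 nM, whereas compound 2 `COc1cc(CCc2ccccn2)cc(OC)c1O` gives 3060 nM, a gap beyond the usual scatter. Compound 3 `COc1cc(CCc2ccc(Cl)cc2)cc(OC)c1O` is compound 1 with a single change: chloro in place of fluoro on an aromatic carbon. Within the data shown here, no measured pair shows what such a swap does here, so the step expected from compound 1 to compound 3 is modest, a 1.3-fold lower number from compound 1 to compound 3 (0.12 log units; within the scatter), toward a slightly lower number or none beyond the scatter. Compound 3 is therefore estimated at 900 nM, within a range from 400 nM to 2000 nM.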

Compound 3, half-maximal inhibitory concentration: 330 nM
Compound 3: the middle estimate sits 2.7-fold (0.44 log units) above what was measured; measured number below the stated range.
By their numbers in this assay, from the lowest: compound 3; then compound 1; then compound 2.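

In this assay the step of a 3.6-fold lower number from compound 1 to compound 3 (0.56 log units; beyond the scatter) shows that this position, on an aromatic carbon para to a large group, is sensitive to which halogen it carries. The change is a single heavy atom, with no ring, hydrogen-bond donor, acceptor or net charge entering or leaving, yet the number moves beyond the usual scatter. Nothing available explains why chloro gives the lower number. Going by these compounds, whether bromo, a methyl group or an amine at the same place would lower the number further stays open. So does whether the same swap would have a similar effect on a different core.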